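Bromo to chloro exchange at two places in the series

The compounds below may be only part of what the source reports. "The series", "measured", "known", "first", "only" and "open" are said of these compounds alone.

Measured compounds:
compound 1, `COC(=O)[C@@]1(C)CCC=C2[C@@H]1CC[C@@H](C)[C@]2(C)Cc1c[nH]c2ccc(Br)cc12`: 20000 nM
compound 2, `COC(=O)[C@@]1(C)CCC=C2[C@@H]1CC[C@@H](C)[C@]2(C)Cc1c[nH]c2ccc(Cl)cc12`: 20000 nM
compound 3, `COC(=O)[C@@]1(C)CCC=C2[C@@H]1CC[C@@H](C)[C@]2(C)Cc1c(C)[nH]c2c(Br)cccc12`: 38000 nM

All three were run in a functional assay on WiDr cells (Homo sapiens) for inhibition, read by sulforhodamine B assay, with a stated time of 48 h; a lower number here means a stronger inhibitor of growth, a higher number a weaker inhibitor of growth. Compound 1 and compound 2 share one core and differ only in that (chloro in place of bromo on an aromatic carbon); the step of no change at the digits printed from compound 1 to compound 2 (within the scatter). Compound 3 carries a different core, and the difference between the two cores is not broken down here; in this assay compound 3 gives 38000 nM, which lies within the scatter of compound 1 and of compound 2.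

The unmeasured compound 4, `COC(=O)[C@@]1(C)CCC=C2[C@@H]1CC[C@@H](C)[C@]2(C)Cc1c(C)[nH]c2c(Cl)cccc12`, relates to compound 3 as compound 2 relates to compound 1: chloro in place of bromo on an aromatic carbon. The place is not the same word for word: in compound 1 and compound 2 the exchanged halogen sits meta to a fused ring and para to a fused ring, whereas in compound 3 and compound 4 it sits ortho to a fused ring and meta to a fused ring. It is therefore the same kind of change, not the same change, and the second core is otherwise untested.

For compound 4 the expected step is no change at the digits printed from compound 3 to compound 4 (within the scatter) because no change at the digits printed from compound 1 to compound 2 (within the scatter). Compound 4 is thus expected near 38000 nM in this assay. The expected range for compound 4 runs from 18000 nM to 80000 nM, widened to allow for the untested core.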

Compound 4, concentration for 50% growth inhibition: 29000 nM
The estimate for compound 4 lay 1.3-fold (0.12 log units) above the measured number; low and high end bracket the measured number.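

In this assay, chloro in place of bromo on an aromatic carbon gives a 1.3-fold lower number from compound 3 to compound 4 (0.12 log units; within the scatter), so on the second core, as on the first, the exchange leaves the growth-inhibition number within the scatter. The two pairs agree, and the change carries from one core to the other as a step too small to read: the same change on two cores in this assay, no change at the digits printed (within the scatter) from compound 1 to compound 2 and a 1.3-fold lower number (0.12 log units; within the scatter) from compound 3 to compound 4, 1.3-fold (0.12 log units) apart, within the scatter of two such steps. This shows only that the two halogens are interchangeable in these two pairs, on these two cores, with the halogen at a different place on each; it does not separate the effect of the core from that of the place, gives no step of readable size to carry over, and offers no cause for the result.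

Still open, from the compounds shown here alone, is what happens when the halogen on the aromatic carbon gives way to a group of another kind, such as fluoro, methoxy, nitrile or an amine, or when a carboxylic acid stands in place of the methyl ester. Also open, going by these compounds, is whether the interchangeability of bromo and chloro holds on a core that gives much lower numbers, or in other cell lines.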